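From 2-Bromophenyl to 3-Bromophenyl: A Small Expected Gain

The source may hold more compounds than are shown below. What is called first, only, known or untested is meant among the compounds shown, and "the series" means these compounds.

In a functional assay on HL-60 cells (Homo sapiens) for antiproliferative activity, with a stated time of 72 h (on this read-out lower numbers stand for stronger inhibition and higher numbers for weaker inhibition), three compounds sharing one core have been measured. Compound 1 `OC[C@H]1O[C@@H](n2cnc3c(NCc4ccccc4F)ncnc32)[C@H](O)[C@@H]1O` gives 3200 nM, compound 2 `OC[C@H]1O[C@@H](n2cnc3c(NCc4ccc(Cl)cc4)ncnc32)[C@H](O)[C@@H]1O` gives 1700 nM, and compound 3 `OC[C@H]1O[C@@H](n2cnc3c(NCc4ccccc4Br)ncnc32)[C@H](O)[C@@H]1O` gives 6600 nM. Compound 3 has the highest number of the three, which makes it the weakest inhibitor here, and its steps to both of the others lie beyond the scatter.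

The next compound, compound 4 `OC[C@H]1O[C@@H](n2cnc3c(NCc4cccc(Br)c4)ncnc32)[C@H](O)[C@@H]1O`, carries 3-bromophenyl in place of 2-bromophenyl on a saturated chain carbon bound to a nitrogen on an aromatic ring.

Within the data shown here, no measured pair makes this exact change, so the evidence is indirect. Replacing fluoro with bromo on the aromatic carbon gave a 2.1-fold higher number from compound 1 to compound 3 (0.31 log units; beyond the scatter). Replacing 4-chlorophenyl with 2-bromophenyl gave a 3.9-fold higher number from compound 2 to compound 3 (0.59 log units; beyond the scatter). The remaining measured step, a 1.9-fold lower number from compound 1 to compound 2 (0.27 log units; within the scatter), is smaller. All of these steps are small or modest, and compound 3 sits at the high end of the measured values, so a small move toward a lower number is the likeliest outcome, one that may not clear the scatter. The expected change is a 1.9-fold lower number from compound 3 to compound 4 (0.28 log units; within the scatter). Compound 4 is estimated at 3500 nM, with an expected range of 1500 nM to 8000 nM.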

Compound 4, half-maximal inhibitory concentration: 8000 nM
The estimate for compound 4 lay 2.3-fold (0.36 log units) below the measured number, within the range that was stated.
By their numbers in this assay, from the lowest: compounds 2 and 1 (each within the scatter of the next); then compounds 3 and 4 (each within the scatter of the next).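

In this assay, putting 3-bromophenyl in place of 2-bromophenyl gives a 1.2-fold higher number from compound 3 to compound 4 (0.08 log units; within the scatter), so on this read-out the two placements of the bromine cannot be told apart, even though the same atoms are joined differently. The new compound also stays clearly apart from the other two, with a 4.7-fold higher number from compound 2 to compound 4 (0.67 log units; beyond the scatter) and a 2.5-fold higher number from compound 1 to compound 4 (0.40 log units; beyond the scatter), so among these four compounds both bromophenyl groups go with higher numbers than 2-fluorophenyl and 4-chlorophenyl, and no compound shown goes against this. No measurement is available here that could explain this pattern.

The compounds shown leave open whether 4-bromophenyl would stay with the two bromo compounds or sit with the 4-chlorophenyl of compound 2, so the effect of changing the halogen cannot yet be separated from that of changing its place. Also open, going by these compounds, is how the number would respond if the halogen on the phenyl group gave way to a different kind of group, such as a methoxy group, an amine or a carboxylic acid.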